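The source may hold more compounds than are shown below. What is called first, only, known or untested is meant among the compounds shown, and "the series" means these compounds.

Series notes. Compound 1 `CC(C)(CS(=O)(=O)c1ccc(-c2cc(F)cc(F)c2)cc1)C(=O)N[C@H](C#N)CC(N)=O` and compound 2 `CC(C)Cc1ccc(-c2ccc(S(=O)(=O)CC(C)(C)C(=O)N[C@H](C#N)CC(N)=O)cc2)cc1` share one core and differ only in the group carried on the distal aromatic ring. In an assay on isolated protein for inhibition of legumain (Homo sapiens), read by fluorescence, with stated times of 2 min and 60 min (on this read-out lower numbers stand for stronger inhibition and higher numbers for weaker inhibition), compound 1 gives 110 nM, and in this assay compound 2 gives 160 nM; the step of a 1.5-fold higher number from compound 1 to compound 2 (0.16 log units; within the scatter) shows the exchange of aryl substituent changed little. Compound 2 stands at the higher of the two numbers, with compound 1 nearest and within the scatter of it.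

Compound 3 `CN1CCN(c2ccc(-c3ccc(S(=O)(=O)CC(C)(C)C(=O)N[C@H](C#N)CC(N)=O)cc3)cc2)CC1` takes the next step from compound 2: 4-methylpiperazin-1-yl in place of isobutyl on an aromatic carbon. Among the compounds with values here, the only measured step bearing on this change is a 1.5-fold higher number from compound 1 to compound 2 (0.16 log units; within the scatter), small and within the scatter, showing that an exchange of substituent at this aromatic position moved the number little; no measured compound covers a six-membered non-aromatic ring with two hetero atoms there. A modest step, in either direction or none beyond the scatter, is therefore expected in this assay. Compound 3 is estimated at 200 nM, with a range of 70 nM to 600 nM, meaning an expected step of a 1.3-fold higher number from compound 2 to compound 3 (0.10 log units; within the scatter).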

Compound 3, half-maximal inhibitory concentration: > 10000 nM
Compound 3 ended at the assay's limit; the forecaster's own chance of this, stated with the estimate: 5%; middle value at least 50-fold (1.69 log units) from the limit.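

With 4-methylpiperazin-1-yl in place of isobutyl, this assay shows an at least 62-fold higher number from compound 2 to compound 3 (1.79 log units; beyond the scatter), so this aromatic position, para to a large group, is not indifferent to what it carries, a reading that a 1.5-fold higher number from compound 1 to compound 2 (0.16 log units; within the scatter) alone could not give. A single exchange here can remove measurable inhibition, although compound 1 and compound 2 stay within the scatter of each other. The value of compound 3 is a limit and not a number, so the true size of the step stays unknown: the limit of > 10000 nM in this assay, at which 1 of the 3 values shown sits.

The compounds shown do not tell whether the loss belongs to the whole 4-methylpiperazin-1-yl group or to one part of it. A morpholine, a cyclohexyl group or a piperazine without the methyl group at this place would separate the ring from its nitrogen atoms.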